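A few compounds are considered here, and "the series" means these few. Any claim that something is new, unique, unknown or untested is made for them only; others in the source may bear on it.

Compound 1 `COc1cc(-c2cc(/C=C/C(=O)c3ccc(N)cc3)[nH]n2)cc(OC)c1OC` has the highest number of the three compounds measured in a functional assay on K562 cells (Homo sapiens) for cytotoxicity, read by sulforhodamine B assay, with a stated time of 48 h, tested at 100 uM (on this read-out higher numbers stand for a weaker effect at the one concentration tested and lower numbers for a stronger effect), where compound 1 gives -3%. Compound 2 `COc1ccc(-c2cc(/C=C/C(=O)c3cc(OC)c(OC)c(OC)c3)[nH]n2)cc1OC` sits nearest to it, and in this assay compound 2 gives -16%, a gap beyond the scatter. Compound 3 `COc1ccc(-c2cc(/C=C/C(=O)c3ccc(N)cc3)[nH]n2)cc1` lies furthest away, and in this assay compound 3 gives -60%. Compound 4 `COc1ccc(C(=O)/C=C/c2cc(-c3cc(OC)c(OC)c(OC)c3)n[nH]2)cc1OC` has not yet been measured; it differs from compound 1 by 3,4-dimethoxyphenyl in place of 4-aminophenyl on a carbonyl carbon. No pair of measured compounds differs in a single place, so the effect of this change is not shown directly by the numbers in hand. A modest downward step is expected, a number 12 percentage points lower from compound 1 to compound 4 (beyond the scatter), near the edge of the scatter. Compound 4 is estimated at -15% in this assay, with a range from -45% to 10%.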

Compound 4, a percentage reported as activity, at one concentration (the size of the read-out at that concentration, not a potency): -15%
Compound 4: middle estimate and measured number agree at the digits printed, within the range that was stated.
By their numbers in this assay, from the lowest: compound 3; then compounds 2 and 4 (each within the scatter of the next); then compound 1.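

Within the data shown here, with a number 12 percentage points lower from compound 1 to compound 4 (beyond the scatter) in this assay, 3,4-dimethoxyphenyl in place of 4-aminophenyl gives the first reading of a change in one place, and it shows that the group on this carbonyl carbon affects the number. The amine is not needed for this read-out to hold a negative value, as compound 4 shows. Nothing at hand gives a reason for the step. From the compounds shown here alone, whether 4-hydroxyphenyl, 4-acetamidophenyl or 4-carboxyphenyl on this carbonyl carbon would shift the number remains open. So does the size of this change on other cores.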